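Series notes: shifting the methyl on the pyridinyl group

The source may hold more compounds than are shown below. What is called first, only, known or untested is meant among the compounds shown, and "the series" means these compounds.

Two compounds of this series carry a number in a functional assay on A-375 cells (Homo sapiens) for cytotoxicity, read by MTT assay, with a stated time of 72 h, tested at 1 uM; on this read-out higher numbers stand for more inhibition of growth at the one concentration tested and lower numbers for less inhibition of growth. Compound 1 `Cc1cccc(/C(N)=N/NC(=S)N2CCN(c3ccccn3)CC2)n1` gives 58.4% in this assay. Compound 2 `N/C(=N\NC(=S)N1CCCC1)c1ccc(F)cn1` gives 57.9% in this assay. Compound 1 stands next to compound 2, and the gap between the two lies within the usual scatter of this assay, so the two cannot be told apart on these numbers.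

Compound 3 `Cc1ccnc(/C(N)=N/NC(=S)N2CCN(c3ccccn3)CC2)c1` has not yet been measured in this assay. It differs from compound 1 in one place: 4-methylpyridin-2-yl in place of 6-methylpyridin-2-yl on a carbon with a double bond to nitrogen. Among the measured compounds shown here, no pair of measured compounds differing in one place exists, so no measured step bears on this change; compounds 1 and 2 differ in more than one place.

The change keeps the same atoms and moves only the methyl within the pyridinyl group, so no step beyond the scatter is expected in this assay. The estimated step of a number 3.4 percentage points lower from compound 1 to compound 3 (within the scatter) is expected to stay inside the scatter. Compound 3 is expected to give about 55% in this assay, with a range from 40% to 70%.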

Compound 3, percent growth inhibition at one concentration: 64.4%
Beside the measured number, compound 3's estimate is 9.4 percentage points below it, and the stated range covers the measured number.
By their numbers in this assay, from the lowest: compounds 2, 1 and 3 (each within the scatter of the next).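

In this assay the series now has its first measured step between compounds that differ in one place: a number 6 percentage points higher from compound 1 to compound 3 (within the scatter). With 4-methylpyridin-2-yl in place of 6-methylpyridin-2-yl on the carbon with a double bond to nitrogen, the read-out cannot be told apart from that of compound 1, so at this one concentration the two placements of the methyl within the pyridinyl group are equivalent within the scatter, whereas the earlier pair, differing in more than one place, could say nothing about this position. Nothing measured here offers an explanation for this result, and none is given.

Open, on these data alone, is whether the methyl matters at all, since a plain pyridin-2-yl group, or a methoxy or trifluoromethyl group at the same places, would test whether this part of the molecule can change the read-out beyond the scatter. A single concentration also leaves open whether compound 1 and compound 3 would still match across a full concentration range.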